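The compounds below may be only part of what the source reports. "The series", "measured", "known", "first", "only" and "open" are said of these compounds alone.

Notes on the series. In a functional assay on HeLa cells (Homo sapiens) for cytotoxicity, read by MTT assay, with a stated time of 72 h, tested at 1 uM (a higher number here means more inhibition of growth at the concentration tested, a lower number less inhibition of growth), compound 1 `Cc1ccnc(/C(N)=N/NC(=S)N2CCOCC2)c1` gives 39.1% and compound 2 `Cc1ccnc(/C(N)=N/NC(=S)N2CCSCC2)c1` gives 41.1%. Within the data shown here, the one step that can be read directly is a number 2 percentage points higher from compound 1 to compound 2 (within the scatter). Compound 3 `N/C(=N\NC(=S)N1CCCCC1)c1ccccn1` gives 15.5% in this assay; this is the lowest of the three numbers, with compound 1 the nearest and compound 2 the furthest, both gaps beyond the scatter. Compound 3 differs from compound 1 in two places at once, so the gap between the two cannot be split into parts.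

Compound 4 `Cc1ccnc(/C(N)=N/NC(=S)N2CCCCC2)c1` is not yet measured. The change from compound 3 is methyl in place of hydrogen on an aromatic carbon. No measured step in this assay bears on this change: the only step shown, from compound 1 to compound 2, alters the ring on the thiocarbonyl carbon and leaves the methyl untouched. Among the measured compounds shown here, what can be noted is only that both compounds carrying the methyl, compound 1 and compound 2, sit well above compound 3 in this assay, while the ring on the thiocarbonyl carbon also differs between them and compound 3.

For compound 4 the expectation is therefore a modest rise, a number 11.5 percentage points higher from compound 3 to compound 4 (beyond the scatter), landing at an estimated 27% with a range from 10% to 46%.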

Compound 4, percent growth inhibition at one concentration: 15.3%
The estimate for compound 4 lay 11.7 percentage points above the measured number; the measured number falls inside the stated range.
By their numbers in this assay, from the lowest: compounds 4 and 3 (each within the scatter of the next); then compounds 1 and 2 (each within the scatter of the next).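

In this assay methyl in place of hydrogen on an aromatic carbon, opposite the ring nitrogen, gives a number 0.2 percentage points lower from compound 3 to compound 4 (within the scatter) and so, with piperidin-1-yl on the thiocarbonyl carbon, this position shows no response to the change. With the methyl held constant, the ring on the thiocarbonyl carbon does register: piperidin-1-yl in place of morpholin-4-yl gives a number 23.8 percentage points lower from compound 1 to compound 4 (beyond the scatter) and piperidin-1-yl in place of thiomorpholin-4-yl gives a number 25.8 percentage points lower from compound 2 to compound 4 (beyond the scatter) and the gap first seen between compound 3 and the two methyl compounds therefore tracks the ring in this set, not the methyl. No evidence at hand accounts for either the silent methyl step or the two ring steps.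

Still open, on these data alone, is whether the methyl is equally silent when morpholin-4-yl or thiomorpholin-4-yl sits on the thiocarbonyl carbon. Also open, as far as these compounds go, is whether a methoxy group, an amine or a carboxylic acid at the methyl position would move the number, and whether an open-chain dimethylamino group on the thiocarbonyl carbon would side with compound 1 and compound 2 or with compound 4.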